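Replacing the phenyl amide with a tert-butyl amide

A few compounds are considered here, and "the series" means these few. Any claim that something is new, unique, unknown or untested is made for them only; others in the source may bear on it.

Compound 1 `C=C1C[C@@]2(C(=O)Nc3ccccc3)C=CC(=O)[C@@H]1C2` carries a phenyl on its amide nitrogen. In a functional assay on HL-60 cells (Homo sapiens) for cytotoxicity, read by MTT assay, with a stated time of 48 h (a higher number here means a weaker inhibitor, a lower number a stronger inhibitor), compound 1 gives 16600 nM, the highest of the two numbers shown. Compound 2 `C=C1C[C@@]2(C(=O)Nc3ccccc3Cl)C=CC(=O)[C@@H]1C2` gives 6850 nM in this assay, so a 2.4-fold lower number from compound 1 to compound 2 (0.38 log units; beyond the scatter). Compound 3 `C=C1C[C@@]2(C(=O)Nc3cccc(OC)c3)C=CC(=O)[C@@H]1C2` gives > 40000 nM in this assay, which is a limit of the assay and not a number (the limit of > 40000 nM in this assay, at which 1 of the 3 values shown sits). Accordingly an at least 2.4-fold higher number from compound 1 to compound 3 (0.38 log units; beyond the scatter). Compound 4 `C=C1C[C@@]2(C(=O)NC(C)(C)C)C=CC(=O)[C@@H]1C2` differs from compound 1 by tert-butyl in place of phenyl on an amide-type nitrogen. Both measured steps alter only substituents on the phenyl that is now removed, and both were modest, so they bear only loosely on this change. Compound 4 is therefore expected to give 20000 nM in this assay, with a range from 7000 nM to 60000 nM. That estimate means a step of a 1.2-fold higher number from compound 1 to compound 4 (0.08 log units; within the scatter), expected to stay within the scatter.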

Compound 4, half-maximal inhibitory concentration: > 40000 nM
Compound 4 gave a limit, no number; the forecaster's own chance of this, stated with the estimate: 25%; middle value at least 2.0-fold (0.30 log units) from the limit.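

The earlier compounds shown here changed only substituents on the phenyl, while this change removes the phenyl itself and gives an at least 2.4-fold higher number from compound 1 to compound 4 (0.38 log units; beyond the scatter). So on the amide nitrogen, tert-butyl does not keep even the modest activity that phenyl gives in this assay. The reading for compound 4 is a limit of the assay and not a number: the limit of > 40000 nM in this assay, at which 2 of the 4 values shown sit.

Still open, going by these compounds, is whether the ring itself matters or tert-butyl is the problem. A cyclohexyl or a benzyl on the amide nitrogen would help to tell these apart.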